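This account rests on a few compounds, and the source may have more. Where it says the series, first, only, none or still open, it means among the compounds named here.

Measured compounds and their values:

Compound 1, `COc1ccc(C(=O)N2CCN(CC(=O)N3CCN(CCCc4c[nH]c5ccccc45)CC3)CC2)cc1`: 156000 nM
Compound 2, `Cc1ccc(C(=O)N2CCN(CC(=O)N3CCN(CCCc4c[nH]c5ccccc45)CC3)CC2)cc1`: 159000 nM
Compound 3, `O=C(CN1CCN(C(=O)c2cccc(Br)c2)CC1)N1CCN(CCCc2c[nH]c3ccccc23)CC1`: 80700 nM

All three were tested in an ADME assay on HEK293 cells (Homo sapiens) for cytotoxicity, read by MTT assay, with a stated time of 72 h; a higher number here means a weaker inhibitor, a lower number a stronger inhibitor. Compound 3 gives the lowest of the three numbers, but its gap to compound 1, a 1.9-fold lower number from compound 1 to compound 3 (0.29 log units; within the scatter), and its gap to compound 2, a 2.0-fold lower number from compound 2 to compound 3 (0.29 log units; within the scatter), both fall within the usual scatter, so the three compounds cannot be told apart on these numbers. The same holds for a 1.0-fold higher number from compound 1 to compound 2 (0.01 log units; within the scatter).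

Compound 4, `COc1ccc2[nH]cc(CCCN3CCN(C(=O)CN4CCN(C(=O)c5cccc(Br)c5)CC4)CC3)c2c1`, is the next compound to be measured in this assay. It differs from compound 3 in one place: methoxy in place of hydrogen on an aromatic carbon. This change sits on the 1H-indol-3-yl part of the shared core, a position that none of the three measured steps touches; those steps all vary the group on the carbonyl carbon at the other end of the molecule, and each of them stayed within the scatter. For the measured compounds named here, the only guidance is that every change seen so far left the number essentially where it was, and that the three measured values lie close together.

The expected step from compound 3 to compound 4 is therefore a 1.1-fold higher number from compound 3 to compound 4 (0.05 log units; within the scatter), that is, no step beyond the scatter. The value for compound 4 is expected at 90000 nM, with a range from 40000 nM to 200000 nM.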

Compound 4, half-maximal inhibitory concentration: 57000 nM
Beside the measured number, compound 4's estimate is 1.6-fold (0.20 log units) above it; measured number inside the range.
By their numbers in this assay, from the lowest: compounds 4, 3, 1 and 2 (each within the scatter of the next, the first and the last beyond it).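

In this assay, for the compounds shown here, methoxy in place of hydrogen turns the 1H-indol-3-yl group into 5-methoxy-1H-indol-3-yl and gives a 1.4-fold lower number from compound 3 to compound 4 (0.15 log units; within the scatter) on a part of the shared core that no earlier step had touched. Going by these compounds alone, the earlier steps varied only the group on the carbonyl carbon, so this is the first sign that a change elsewhere in the molecule can also stay within the scatter, although it rests on this single pair of compounds. Nothing shown here gives a measured reason for this result or links it to any property of the methoxy group.

Methoxy is the only group shown on this ring, so it remains open whether a fluorine atom, a hydroxyl group or an amine at the same carbon would also stay within the scatter. From the compounds shown here alone, it is also open whether the same change would give a similar result with the 4-methoxyphenyl or 4-methylphenyl group on the carbonyl carbon in place of the 3-bromophenyl group.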